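The source may report more compounds than this note shows. Statements on the series, on what has been measured and on what is new or still open speak of the compounds shown alone.

Three compounds have been measured in a functional assay on HEK293 cells for agonist activity at 5-hydroxytryptamine receptor 7 (Homo sapiens), read by a luciferase reporter and beta-arrestin recruitment, with a stated time of 22 h; on this read-out higher numbers stand for larger maximal responses and lower numbers for smaller maximal responses:

Compound 1 `COc1ccccc1-c1cc(C2CCNC2)ccc1Cl` gives 54%.
Compound 2 `COc1ccccc1-c1cc(CN(C)C)ccc1Cl` gives 43%.
Compound 3 `CCCCNCc1ccc(Cl)c(-c2ccccc2OC)c1` gives "not active" (no number reported).

Compound 3 stands apart from the other two: in this assay compound 3 is reported only as "not active" (no number reported), with no single number to place it against compound 1 or compound 2. The next compound, compound 4 `CCN(CC)Cc1ccc(Cl)c(-c2ccccc2OC)c1`, has the same atoms as compound 3 joined differently: diethylamino in place of butylamino on a saturated chain carbon bound to an aromatic carbon.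

Going by the values given here, only one measured step exists, a number 11 percentage points lower from compound 1 to compound 2 (beyond the scatter), and it concerns a different change at a different place on the shared core, so it offers a loose guide at best. It does show that a compound carrying a small tertiary amine on that side chain, compound 2 with 43%, can still give a clear response. Compound 4 also carries a tertiary amine there, while compound 3, which gave no response, carries a secondary one. Without a step that maps this exact change, the expectation is a modest response with wide uncertainty, and a real chance that the assay again reports no number. For compound 4 the expected maximal response in this assay is estimated at 30%, within a range of 0% to 55%.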

Compound 4, largest response reached (Emax), in percent of the reference or control that the assay uses: "not active" (no number reported)
The entry for compound 4 holds no number; the estimate stays without a comparison.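

In this assay compound 3 gives "not active" (no number reported) and compound 4 gives "not active" (no number reported) so no step can be read between these two compounds. They leave open whether diethylamino in place of butylamino changes the maximal response at all, as neither compound offers a number to compare. No supporting evidence bears on this result.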